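Moving the Naphthalene Attachment Point onto Compound 3

The source may hold more compounds than are shown below. What is called first, only, known or untested is meant among the compounds shown, and "the series" means these compounds.

Of the compounds shown here, three have been measured in a functional assay on RPMI 8402 cells (Homo sapiens) for cytotoxicity; a higher number here means a weaker inhibitor, a lower number a stronger inhibitor. Compound 1 `N#Cc1ccc2[nH]c(-c3ccc4[nH]c(-c5cccc6ccccc56)nc4c3)nc2c1` gives 650 nM. Compound 2 `N#Cc1ccc2[nH]c(-c3ccc4[nH]c(-c5ccc6ccccc6c5)nc4c3)nc2c1` gives 130 nM. Compound 3 `CN1CCN(c2ccc3[nH]c(-c4ccc5[nH]c(-c6cccc7ccccc67)nc5c4)nc3c2)CC1` gives 330 nM. Compound 1 and compound 2 differ by naphthalen-2-yl in place of naphthalen-1-yl on an aromatic carbon, and this change gives a 5.0-fold lower number from compound 1 to compound 2 (0.70 log units; beyond the scatter). Compound 1 and compound 3 differ in their cores by 4-methylpiperazin-1-yl in place of cyano on an aromatic carbon, which gives a 2.0-fold lower number from compound 1 to compound 3 (0.29 log units; within the scatter), a step within the scatter.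

Compound 4 `CN1CCN(c2ccc3[nH]c(-c4ccc5[nH]c(-c6ccc7ccccc7c6)nc5c4)nc3c2)CC1` has not yet been measured in this assay. It differs from compound 3 by naphthalen-2-yl in place of naphthalen-1-yl on an aromatic carbon, the same change that separates compound 1 from compound 2, with the same surroundings. The expectation for compound 4 therefore rests on one measured precedent: the step from compound 1 to compound 2 of a 5.0-fold lower number from compound 1 to compound 2 (0.70 log units; beyond the scatter). If that step carries over onto the core of compound 3, compound 4 is expected to show a 4.7-fold lower number from compound 3 to compound 4 (0.67 log units; beyond the scatter). Within the data shown here, on that basis compound 4 is estimated at 70 nM, with a plausible range from 25 nM to 200 nM, since only a single precedent supports the transfer.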

Compound 4, half-maximal inhibitory concentration: 110 nM
Compound 4: the middle estimate sits 1.6-fold (0.20 log units) below what was measured; low and high end bracket the measured number.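

In this assay, naphthalen-2-yl in place of naphthalen-1-yl gives a 3.0-fold lower number from compound 3 to compound 4 (0.48 log units; beyond the scatter), and this step does not differ measurably from the one seen on the other core: the same change on two cores in this assay, a 5.0-fold lower number (0.70 log units; beyond the scatter) from compound 1 to compound 2 and a 3.0-fold lower number (0.48 log units; beyond the scatter) from compound 3 to compound 4, 1.7-fold (0.22 log units) apart, within the scatter of two such steps. The exchange of cyano for 4-methylpiperazin-1-yl, read on the naphthalen-2-yl compounds, gives a 1.2-fold lower number from compound 2 to compound 4 (0.07 log units; within the scatter), and it likewise agrees with its earlier counterpart, so neither change depends detectably on the other here: the same change on two cores in this assay, a 2.0-fold lower number (0.29 log units; within the scatter) from compound 1 to compound 3 and a 1.2-fold lower number (0.07 log units; within the scatter) from compound 2 to compound 4, 1.7-fold (0.22 log units) apart, within the scatter of two such steps. This supports carrying the naphthalene change between these two cores, but it rests on a single pair of cores and does not show that the step would hold on any other core or fix its size more closely than the scatter allows.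

The compounds shown leave open whether the same step would appear with an amine or a carboxylic acid in the place held by cyano or 4-methylpiperazin-1-yl. They also leave open how a longer chain or an amide in place of the naphthalene group would compare with either naphthalene attachment.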